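Swapping the aryl group of compound 3

The compounds below may be only part of what the source reports. "The series", "measured", "known", "first", "only" and "open" are said of these compounds alone.

Compound 1 `Cc1ccc(C)c(-c2nc(CN3CCC(C(=O)NCCCN4C[C@H](C)C[C@H](C)C4)CC3)c(C)o2)c1`: 0.5 h
Compound 2 `Cc1cccc(F)c1-c1nc(CN2CCC(C(=O)NCCCN3C[C@H](C)C[C@H](C)C3)CC2)c(C)o1`: 0.0733 h
Compound 3 `COc1cccc(F)c1-c1nc(CN2CCC(C(=O)NCCCN3C[C@H](C)C[C@H](C)C3)CC2)c(C)o1`: 0.143 h

All three compounds were measured in an ADME assay on microsomes from liver (Rattus norvegicus) for metabolic stability, read by LC-MS, using NADPH, at 37 degrees C; on this read-out higher numbers stand for a longer-lived compound and lower numbers for a shorter-lived compound. Compound 3, at 0.143 h, stands clearly short of compound 1 and within the scatter of compound 2. Among the compounds with values here, the steps that bear on the next change are a 6.8-fold lower number from compound 1 to compound 2 (0.83 log units; beyond the scatter) and a 3.5-fold lower number from compound 1 to compound 3 (0.54 log units; beyond the scatter), both modest and beyond the scatter, and a 2.0-fold higher number from compound 2 to compound 3 (0.29 log units; within the scatter), which stays within it.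

Compound 4 `COc1ccc(-c2nc(CN3CCC(C(=O)NCCCN4C[C@H](C)C[C@H](C)C4)CC3)c(C)o2)cc1OC` carries 3,4-dimethoxyphenyl in place of 2-fluoro-6-methoxyphenyl on an aromatic carbon. Within the data shown here, no measured compound carries this group, so the measured steps serve only as a guide to size. Like compound 1, at 0.5 h, compound 4 has no fluorine, which suggests a slight rise at most. The expected step is a 1.4-fold higher number from compound 3 to compound 4 (0.15 log units; within the scatter), so none beyond the scatter is anticipated. Compound 4 is estimated at 0.2 h, with an expected range of 0.07 h to 0.55 h.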

Compound 4, half-life: > 0.5 h
Compound 4: only a limit was reported; the forecaster's own chance of this, stated with the estimate: 3%; middle value at least 2.5-fold (0.39 log units) away from the limit.
By their numbers in this assay, from the lowest: compounds 2 and 3 (each within the scatter of the next); then compound 1.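

In this assay compound 4 gives > 0.5 h, which is a limit of the assay and not a number. At this aromatic carbon, the new aryl group gives an at least 3.4-fold higher number from compound 3 to compound 4 (0.54 log units; beyond the scatter) and an at least 6.8-fold higher number from compound 2 to compound 4 (0.83 log units; beyond the scatter), both beyond the scatter, so the earlier fall from compound 1 can be more than recovered with a group that has no fluorine, and compound 3 shows that a methoxy group alone does not bring this. The same group also gives a number no lower from compound 1 to compound 4 (the limit leaves the size open), a step whose size cannot be read because of the limit: the limit of > 0.5 h in this assay, at which 1 of the 4 values shown sits.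

Going by these compounds, whether the loss of fluorine or the placing of the methoxy groups matters more stays open, and a plain phenyl or a pyridyl group at this position would bear on that. On these data alone, how far compound 4 lies past its limit also remains unknown.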